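From methylcarbamoyl to trifluoromethyl: working notes on the series

The source may report more compounds than this note shows. Statements on the series, on what has been measured and on what is new or still open speak of the compounds shown alone.

Measured so far in a physicochemical assay for solubility, with a stated time of 4 h, at pH 2.0; a lower number here means a less soluble compound, a higher number a more soluble compound:
compound 1 `CC(=O)CCc1cc(C)c(Oc2cc(Nc3ccc(C#N)cc3)c(N)cc2C(F)(F)F)c(C)c1` gives 0.28 ug/mL
compound 2 `CNC(=O)c1cc(N)c(Nc2ccc(C#N)cc2)cc1Oc1c(C)cc(CCC#N)cc1C` gives 44.7 ug/mL
compound 3 `Cc1cc(/C=C/C#N)cc(C)c1Oc1cc(Nc2ccc(C#N)cc2)c(N)cc1[N+](=O)[O-]` gives 0.29 ug/mL

Compound 2 has the highest of the three numbers, and its gaps to compound 1 and to compound 3 both lie beyond the usual scatter. The values of compound 1 and compound 3 lie within the scatter of each other. For the measured compounds named here, compound 2 is also the only measured compound that carries methylcarbamoyl, though three compounds are too few to establish a trend.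

The next compound is compound 4 `Cc1cc(CCC#N)cc(C)c1Oc1cc(Nc2ccc(C#N)cc2)c(N)cc1C(F)(F)F`, still unmeasured. It has trifluoromethyl in place of methylcarbamoyl on an aromatic carbon. Going by the values given here, no two measured compounds differ in one place only, so this change has no direct precedent. The closest guide is compound 1, which also carries trifluoromethyl and gives 0.28 ug/mL, although it differs from compound 4 in another part of the structure. On that evidence, the step of an 89-fold lower number from compound 2 to compound 4 (1.95 log units; beyond the scatter) is expected to be a large fall in this assay, well beyond the scatter. For compound 4 the estimated value is 0.5 ug/mL, with an expected range of 0.1 ug/mL to 3 ug/mL.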

Compound 4, solubility: 0.33 ug/mL
The estimate for compound 4 lay 1.5-fold (0.18 log units) above the measured number, within the range that was stated.
By their numbers in this assay, from the lowest: compounds 1, 3 and 4 (each within the scatter of the next); then compound 2.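

Trifluoromethyl in place of methylcarbamoyl, on the aromatic carbon para to a (4-cyanophenyl)amino group, is now seen as a single change in this assay: a 140-fold lower number from compound 2 to compound 4 (2.13 log units; beyond the scatter) is the first gap in the series that can be read at one position, with the rest of the structure held constant. The two groups both count 4 heavy atoms, so this large step comes with no difference in heavy-atom count, while the hydrogen-bond donor and acceptor counted on methylcarbamoyl are absent from trifluoromethyl. With trifluoromethyl at this position, the chain change of cyano in place of acetyl, two bonds along the chain from an aromatic carbon, gives a 1.2-fold higher number from compound 1 to compound 4 (0.07 log units; within the scatter) and so has no readable effect here.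

Methylcarbamoyl still stands on a single compound, so the compounds shown leave open how a carboxylic acid, a primary carboxamide or an aminomethyl group would read at this position, and whether the chain change would stay as flat with methylcarbamoyl in place. No measurement shown gives a reason for the large step at this position.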